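Shortening the amide tail: piperidinylmethyl to pyrrolidinyl

The source may hold more compounds than are shown below. What is called first, only, known or untested is meant among the compounds shown, and "the series" means these compounds.

Measured compounds:
compound 1, `CC(C)(O)CCN1CCC(NS(=O)(=O)c2cc(S(=O)(=O)c3ccccc3)ccc2C(F)(F)F)CC1`, 200 nM
compound 2, `O=C(C1CCNCC1)N1CCC(NS(=O)(=O)c2cc(S(=O)(=O)c3ccccc3)ccc2C(F)(F)F)CC1`, 120 nM
compound 3, `O=C(CC1CCNCC1)N1CCC(NS(=O)(=O)c2cc(S(=O)(=O)c3ccccc3)ccc2C(F)(F)F)CC1`, 100 nM

All three share one core and differ only in the group carried on the amine nitrogen in the ring. In an assay on isolated protein for displacement of a labelled ligand from secreted frizzled-related protein 1 (Homo sapiens), read by fluorescence polarization, with a stated time of 30 min (on this read-out lower numbers stand for stronger inhibition and higher numbers for weaker inhibition), compound 3 gives the lowest of the three numbers, but its neighbours sit close: a 1.2-fold lower number from compound 2 to compound 3 (0.08 log units; within the scatter) and a 2.0-fold lower number from compound 1 to compound 3 (0.30 log units; within the scatter) are both within the scatter, so no ordering among the three can be claimed.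

Compound 4, `O=C([C@@H]1CCNC1)N1CCC(NS(=O)(=O)c2cc(S(=O)(=O)c3ccccc3)ccc2C(F)(F)F)CC1`, is not yet measured. It differs from compound 3 by pyrrolidin-3-yl in place of (piperidin-4-yl)methyl on a carbonyl carbon. Going by the values given here, the nearest precedent is the step from compound 2 to compound 3, where a methylene was inserted between the ring and the carbonyl carbon, giving a 1.2-fold lower number from compound 2 to compound 3 (0.08 log units; within the scatter), a change within the scatter. The larger exchange from compound 1 to compound 2, a 1.7-fold lower number from compound 1 to compound 2 (0.22 log units; within the scatter), was likewise within the scatter. Every alteration to this tail has so far left this assay essentially unchanged, so for compound 4 the expected step is a 1.3-fold higher number from compound 3 to compound 4 (0.11 log units; within the scatter), that is, none beyond the scatter.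

The estimate for compound 4 in this assay is therefore 130 nM, with a range from 50 nM to 350 nM.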

Compound 4, half-maximal inhibitory concentration in the secreted frizzled-related protein 1 assay: 60 nM
Compound 4: the middle estimate sits 2.2-fold (0.34 log units) above what was measured, within the range that was stated.
By their numbers in the secreted frizzled-related protein 1 assay, from the lowest: compounds 4, 3, 2 and 1 (each within the scatter of the next, the first and the last beyond it).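

Going by these compounds alone, in the secreted frizzled-related protein 1 assay, pyrrolidin-3-yl on the carbonyl carbon gives a 1.7-fold lower number from compound 3 to compound 4 (0.22 log units; within the scatter) and a 2.0-fold lower number from compound 2 to compound 4 (0.30 log units; within the scatter), so compound 4 cannot be separated from either amide with a six-membered ring, yet a 3.3-fold lower number from compound 1 to compound 4 (0.52 log units; beyond the scatter) is the first step in this small set printed as beyond the scatter. In a physicochemical assay for solubility, at pH 7.4 (on this read-out higher numbers stand for higher solubility and lower numbers for lower solubility), compound 3 gives > 100000 nM, which is a limit of the assay and not a number. In the physicochemical assay, compound 4 gives 70000 nM, a measured number. In the physicochemical assay, this change gives an at least 1.4-fold lower number from compound 3 to compound 4 (0.15 log units; that floor lies within the scatter), and only a floor can be read for its size: the limit of > 100000 nM in the physicochemical assay, at which 1 of the 2 values shown sits.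

The compounds shown leave open whether the mirror-image pyrrolidin-3-yl or an azetidin-3-yl on the same carbonyl carbon would read differently from compound 4 in the secreted frizzled-related protein 1 assay. Also open, going by these compounds, is whether the ring nitrogen is needed at all, a question that a cyclopentyl group in this place could address in the secreted frizzled-related protein 1 assay and the physicochemical assay.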